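Para Substituent Swap on a Nitrofuran Chalcone Series

The source may hold more compounds than are shown below. What is called first, only, known or untested is meant among the compounds shown, and "the series" means these compounds.

The measured compounds are three: compound 1 `O=C(/C=C/c1ccc([N+](=O)[O-])o1)c1ccc(Br)cc1`, compound 2 `O=C(/C=C/c1ccc([N+](=O)[O-])o1)c1ccc(I)cc1` and compound 3 `CSc1ccc(C(=O)/C=C/c2ccc([N+](=O)[O-])o2)cc1`. In a functional assay on C6 cells (Rattus norvegicus) for inhibition, read by sulforhodamine B assay, with a stated time of 72 h (a higher number here means that more compound is needed for the effect, a lower number that less compound is needed), compound 1 gives 2700 nM, compound 2 gives 2100 nM and compound 3 gives 1600 nM.

The three differ only in the group on an aromatic carbon of the six-membered carbon ring, para to a large group. Compound 3 carries the lowest number of the three in this assay, but its distance from the others is small: a 1.7-fold lower number from compound 1 to compound 3 (0.23 log units; within the scatter) and a 1.3-fold lower number from compound 2 to compound 3 (0.12 log units; within the scatter), both within the scatter, as is a 1.3-fold lower number from compound 1 to compound 2 (0.11 log units; within the scatter). So far, then, exchanging the group at this place has not moved the read-out beyond what repeated measurements would give.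

Compound 4 `CC(C)(C)c1ccc(C(=O)/C=C/c2ccc([N+](=O)[O-])o2)cc1` continues this line. The change is tert-butyl in place of methylsulfanyl on an aromatic carbon. All three measured steps bear on it, since each swaps one group for another at the same place, and none reached beyond the scatter. On that basis the expected step is a 1.1-fold higher number from compound 3 to compound 4 (0.05 log units; within the scatter), that is, no movement beyond the scatter in either direction. Compound 4 is therefore estimated to give 1800 nM in this assay, with a range from 900 nM to 3600 nM.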

Compound 4, half-maximal effective concentration: 28600 nM
The estimate for compound 4 lay 16-fold (1.20 log units) below the measured number, outside the stated range (above it).
By their numbers in this assay, from the lowest: compounds 3, 2 and 1 (each within the scatter of the next); then compound 4.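

In this assay the group on this aromatic carbon, para to a large group, proves not to be interchangeable after all: the swap to tert-butyl brings an 18-fold higher number from compound 3 to compound 4 (1.25 log units; beyond the scatter), and the picture is the same against the other two groups, with a 14-fold higher number from compound 2 to compound 4 (1.13 log units; beyond the scatter) and an 11-fold higher number from compound 1 to compound 4 (1.03 log units; beyond the scatter). Among the compounds shown here, the earlier swaps among bromo, iodo and methylsulfanyl stayed within the scatter and so showed only that these three groups cannot be told apart here, whereas all three new steps are large, which sets compound 4 apart from the whole set rather than from any single partner. Nothing available on these compounds says what lies behind this step.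

From the compounds shown here alone, with only four compounds, it remains open whether tert-butyl stands alone at this place or marks the start of a wider trend, which groups such as methyl, isopropyl, methoxy, an amine or a carboxylic acid could help to settle. It also remains open whether the same step would appear on a different core or in a different cell line, since everything shown here comes from a single core and from this assay.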